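The compounds below may be only part of what the source reports. "The series", "measured", "known", "first", "only" and "open" are said of these compounds alone.

Of the compounds shown here, three have been measured in a functional assay for inhibition, tested at 100 uM (on this read-out lower numbers stand for less inhibition and higher numbers for more inhibition at the one concentration tested (going by the name of the read-out)), and a fourth awaits its turn. Compound 1 `O=S(=O)(/C=C/S(=O)(=O)c1ccc(Cl)cc1)CC1=NCCO1` gives 85.5% in this assay. Compound 2 `Cc1ccc(S(=O)(=O)/C=C/S(=O)(=O)CC2=NCCO2)cc1` gives 74.2%. Compound 3 `Cc1ccc(S(=O)(=O)c2c[nH]cc2S(=O)(=O)CC2=NCCO2)cc1` gives 78.5%; its value and that of compound 2 lie within the scatter of each other, as do its value and that of compound 1.

Compound 1 and compound 2 differ in one place: chloro in place of methyl on an aromatic carbon. This step gave a number 11.3 percentage points higher from compound 2 to compound 1 (beyond the scatter). Compound 3 is built on a different core from compound 2; how the two cores differ is not broken down here.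

Compound 4 `O=S(=O)(CC1=NCCO1)c1c[nH]cc1S(=O)(=O)c1ccc(Cl)cc1` carries the core of compound 3 with the same change made on it: chloro in place of methyl on an aromatic carbon. Going by the values given here, the only guide is the step seen on the other core from compound 2 to compound 1, and the core itself is different, so the expected step from compound 3 to compound 4 is set a little smaller, at a number 7.5 percentage points higher from compound 3 to compound 4 (within the scatter). On that basis compound 4 is estimated to give 86% in this assay, expected to fall between 76% and 94%.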

Compound 4, a percentage reported as inhibition, at one concentration (the size of the read-out at that concentration, not a potency): 92.1%
The estimate for compound 4 lay 6.1 percentage points below the measured number, and the stated range covers the measured number.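

Replacing the 4-methylphenyl group with a 4-chlorophenyl group gave a number 13.6 percentage points higher from compound 3 to compound 4 (beyond the scatter) in this assay. The change therefore carried over from one core to the other in this series, and its size was much the same on both: the same change on two cores in this assay, a number 11.3 percentage points higher (beyond the scatter) from compound 2 to compound 1 and a number 13.6 percentage points higher (beyond the scatter) from compound 3 to compound 4, 2.3 percentage points apart, within the scatter of two such steps. Going by these compounds alone, this rests on only two pairs of compounds, one change and a reading at one concentration, and it does not show that the step would hold on any further core or that either pair differs in potency.

Among the compounds shown, the aromatic carbon para to a large group carries only methyl or chloro, and whether fluoro, a methoxy group or an amine in that place would read the same remains open. Also open, going by these compounds, is whether the two cores would still respond alike to a change elsewhere, such as a longer chain in place of the ring on the far side of the sulfonyl group.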